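Methyl at the Core of a Formylamino Pyrimidine Series

The compounds below may be only part of what the source reports. "The series", "measured", "known", "first", "only" and "open" are said of these compounds alone.

Three compounds share one scaffold, bearing a methoxybenzylamino group and a furan ring on the shared core, and differ in the substituent on the amino nitrogen. Compound 1 `COc1ccc(CNc2ncnc(-c3ccco3)c2N)cc1` carries the free amine, compound 2 `COc1ccc(CNc2ncnc(-c3ccco3)c2N(C)C)cc1` the dimethylated amine, and compound 3 `COc1ccc(CNc2ncnc(-c3ccco3)c2NC=O)cc1` the formylamino group. In an ADME assay on Vero cells (Chlorocebus sabaeus) for cytotoxicity, read by MTT assay, with a stated time of 72 h (on this read-out lower numbers stand for stronger inhibition and higher numbers for weaker inhibition), compound 1 gives "not determined" (no result reported) and compound 2 gives "not determined" (no result reported). For compound 3 this assay reports only a limit, > 40 ug/mL, so no single number is known for it. Among the compounds with values here, compound 3 therefore stands at the limit of > 40 ug/mL in this assay, at which 1 of the 3 values shown sits, and no comparison between measured compounds can be drawn from the three entries.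

Compound 4 `COc1ccc(CNc2nc(C)nc(-c3ccco3)c2NC=O)cc1` is the unmeasured partner of compound 3. The change is methyl in place of hydrogen on an aromatic carbon, a methyl in place of hydrogen on an aromatic carbon, sitting between two ring nitrogen atoms of the shared core. Since compound 3 sits at the limit, the step is expected to be none beyond the scatter, with compound 4 most likely also returning only a limit in this assay. The estimated step that the limit leaves unreadable from compound 3 to compound 4 is therefore expected to be flat. Compound 4 is expected to give about 50 ug/mL, within a range from 25 ug/mL to 100 ug/mL.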

Compound 4, half-maximal inhibitory concentration: > 40 ug/mL
Compound 4 ended at the assay's limit (the forecaster's own chance of this, stated with the estimate: 80%); the middle value is on the limit's open side.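

In this assay, within the data shown here, compound 3 and compound 4 both end at a limit of the assay rather than at a single number, so no step between them can be read. The compounds shown leave open what the actual values of these two compounds are, and whether methyl in place of hydrogen changes the read-out at all.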